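Cyano for fluoro on a fused aromatic ring

The compounds below may be only part of what the source reports. "The series", "measured", "known", "first", "only" and "open" are said of these compounds alone.

Measured so far:
compound 1 `Fc1cc(Cl)ccc1-c1ccc(Cn2nnc3ccccc32)cn1` gives 3.4 mL/min/g in an ADME assay on microsomes from liver (Mus musculus, strain NMRI) for metabolic stability, tested at 2.5 uM; on this read-out lower numbers stand for slow clearance and higher numbers for fast clearance;
compound 2 `Fc1cc(Cl)ccc1-c1ccc(Cn2nnc3c(F)cccc32)cn1` gives 2.2 mL/min/g in this assay.

Going by the values given here, compound 2 and compound 1 lie within the scatter of each other on this read-out, the only step known being a 1.5-fold lower number from compound 1 to compound 2 (0.19 log units; within the scatter). Compound 3 `N#Cc1cccc2c1nnn2Cc1ccc(-c2ccc(Cl)cc2F)nc1` differs from compound 2 by cyano in place of fluoro on an aromatic carbon. Among the compounds with values here, no measured step exchanges fluoro for cyano, so the single known step, a fluoro for hydrogen, only shows how little this part of the core has moved the number. The expected step of a 1.1-fold higher number from compound 2 to compound 3 (0.06 log units; within the scatter) is therefore none beyond the scatter. For compound 3 the estimate is 2.5 mL/min/g, within 1.2 mL/min/g to 5 mL/min/g.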

Compound 3, intrinsic clearance in a liver preparation (reported as CLH), per the amount of preparation that the assay uses: 1.6 mL/min/g
Compound 3: middle estimate off by 1.6-fold (0.19 log units), on the high side; measured number inside the range.
By their numbers in this assay, from the lowest: compounds 3, 2 and 1 (each within the scatter of the next, the first and the last beyond it).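

In this assay, the exchange of fluoro for cyano on this aromatic carbon gives a 1.4-fold lower number from compound 2 to compound 3 (0.14 log units; within the scatter) and so does not separate the two groups. Against hydrogen at the same carbon, cyano gives a 2.1-fold lower number from compound 1 to compound 3 (0.33 log units; beyond the scatter) and is the first change here to pass the scatter, though only modestly. Nothing shown accounts for this step.

As far as these compounds go, whether an amine or a carboxylic acid on this carbon would move the number further stays open. The compounds shown carry cyano on this one carbon only, so the other carbons of the ring remain unknown.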